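The source may report more compounds than this note shows. Statements on the series, on what has been measured and on what is new or still open speak of the compounds shown alone.

Among the compounds with values here, in a functional assay on HepG2 cells (Homo sapiens) for antiproliferative activity, read by MTT assay, with a stated time of 72 h (on this read-out higher numbers stand for weaker inhibition and lower numbers for stronger inhibition), compound 1 `O=C1NC(O)(CCn2cnc3cncc(Br)c32)C(OCc2ccccc2)=C1OCc1ccccc1` gives 66500 nM, the only exact number available so far. Compound 2 `COc1nc(OC)c2c(ccn2C/C=C2\OC(=O)C(OCc3ccccc3)=C2OCc2ccccc2)n1` is reported only as a limit, > 100000 nM. Compound 3 `Nc1nc(F)c(Cl)c2c1ncn2CCC1(O)NC(=O)C(OCc2ccccc2)=C1OCc1ccccc1` keeps the core of compound 1 and changes one part of it: a group of 12 heavy atoms (6 carbon, 4 nitrogen, 1 fluorine, 1 chlorine; one five-membered aromatic ring with 2 hetero atoms, one six-membered aromatic ring with 1 hetero atom) in place of a group of 10 heavy atoms (6 carbon, 3 nitrogen, 1 bromine; one five-membered aromatic ring with 2 hetero atoms, one six-membered aromatic ring with 1 hetero atom), on a saturated chain carbon, two bonds along the chain from a saturated ring carbon. This exchange takes place on a saturated chain carbon, two bonds along the chain from a saturated ring carbon. Within the data shown here, no measured pair of compounds shows how much such a change matters, so the only anchor is compound 1 at 66500 nM. In this assay, a shift no larger than the usual scatter of repeated measurements is therefore expected, with no firm direction. The expected step of a 1.3-fold lower number from compound 1 to compound 3 (0.12 log units; within the scatter) reflects this caution. For compound 3 the estimated value is 50000 nM, with an expected range from 20000 nM to 100000 nM.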

Compound 3, half-maximal inhibitory concentration: > 100000 nM
Compound 3: only a limit was reported; the forecaster's own chance of this, stated with the estimate: 20%; at least 2.0-fold (0.30 log units) between middle value and limit.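

Within the data shown here, this is the first measured exchange at this place, on a saturated chain carbon, two bonds along the chain from a saturated ring carbon, and in this assay it gives an at least 1.5-fold higher number from compound 1 to compound 3 (0.17 log units; that floor lies within the scatter). That step is a floor and not a size; the floor lies within the scatter, so the result shows no gain from the exchange but does not establish a real loss. The true size of the step cannot be read, as compound 3 reaches only a limit of the assay: the limit of > 100000 nM in this assay, at which 2 of the 3 values shown sit.

The compounds shown do not tell whether the two-ring group on this chain is needed at all, as an amine or a carboxylic acid in its place could read differently in this assay. On these data alone, how a longer chain would behave also remains open.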